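The compounds below may be only part of what the source reports. "The series", "measured", "known", "first", "only" and "open" are said of these compounds alone.

Of the compounds shown here, three sharing one core have been measured in a physicochemical assay for lipophilicity, measured as octanol-water partition (on this read-out lower numbers stand for lower lipophilicity and higher numbers for higher lipophilicity), so far. Compound 1 (`CCN1C(=O)c2c(nc(Cc3ccccc3)n2Cc2ccc(C)cc2)N2C1=N[C@@H]1CCC[C@@H]12`) gives 5.95 and compound 2 (`CCN1C(=O)c2c(nc(C#Cc3ccccc3)n2Cc2ccc(Cl)cc2)N2C1=N[C@@H]1CCC[C@@H]12`) gives 6.19 on this scale. Compound 3 (`CCN1C(=O)c2c(nc(C#Cc3ccccc3)n2Cc2ccc(OC)cc2)N2C1=N[C@@H]1CCC[C@@H]12`) stands lowest of the three at 5.5 on the same scale. Compound 4 (`CCN1C(=O)c2c(nc(C(=O)OC)n2Cc2ccc(OC)cc2)N2C1=N[C@@H]1CCC[C@@H]12`) differs from compound 3 in one group (methoxycarbonyl in place of 2-phenylethynyl on an aromatic carbon), with methoxycarbonyl in place of 2-phenylethynyl on an aromatic carbon. The group that leaves holds a six-membered aromatic ring of carbon only, and the group that enters has no ring. Within the data shown here, no measured step makes this exchange. Among the measured compounds shown here, the only measured single-place step (a number 0.69 log units lower from compound 2 to compound 3 (beyond the scatter)) puts methoxy in place of chloro elsewhere in the molecule, so it bears only loosely here, although it shows that a small exchange can move the number beyond the scatter. For the measured compounds named here, the exchange here involves a bigger group, so a larger downward step than that one is expected in this assay as a judgement that no measured pair tests. The estimate is a step of a number 1.80 log units lower from compound 3 to compound 4 (beyond the scatter) on this scale. For compound 4 the estimated value is 3.7 with an expected range from 3 to 4.4 on this scale.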

Compound 4, partition coefficient: 3.38
Beside the measured number, compound 4's estimate is 0.32 log units above it; the measured number falls inside the stated range.
By their numbers in this assay, from the lowest: compound 4; then compound 3; then compounds 1 and 2 (each within the scatter of the next).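

In this assay, placing methoxycarbonyl on this aromatic carbon, between two ring nitrogen atoms, in place of 2-phenylethynyl gives a number 2.12 log units lower from compound 3 to compound 4 (beyond the scatter) on the scale. Among these compounds, this exchange moves the number further than the one earlier step, methoxy in place of chloro elsewhere in the molecule, which gave a number 0.69 log units lower from compound 2 to compound 3 (beyond the scatter) and so left open how much this position could shift the value. Nothing measured here explains the size of the new step.

On these data alone, this single exchange removes the aromatic ring and the triple bond and brings in two hydrogen-bond acceptors all at once, so the share of each in the step stays open. As far as these compounds go, how a plain ethyl chain, an amine or a carboxylic acid on this carbon would compare with methoxycarbonyl also remains unknown.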